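The source may report more compounds than this note shows. Statements on the series, on what has been measured and on what is new or still open speak of the compounds shown alone.

Of the compounds shown here, three have been measured in an ADME assay on Huh-7 cells (Homo sapiens) for cytotoxicity, read by MTT assay, with a stated time of 72 h (on this read-out higher numbers stand for lower toxicity in this test and lower numbers for higher toxicity in this test), and each result is a limit of that test rather than a number.
Compound 1 `CCOC(=O)c1sc2nc(C3CC3)cc(C(F)(F)F)c2c1N`: > 20000 nM.
Compound 2 `CCOC(=O)c1oc2nc(-c3ccccc3)cc(C(F)(F)F)c2c1N`: > 20000 nM.
Compound 3 `Nc1c(C(=O)O)sc2nc(-c3ccccc3)cc(C(F)(F)F)c12`: > 20000 nM.

Compound 3 therefore stands at the limit of this assay, with no number of its own, and the same holds for the two other compounds: the limit of > 20000 nM in this assay, at which 3 of the 3 values shown sit. Compound 4 `Nc1c(C(=O)N2CCc3sccc3C2)sc2nc(-c3ccccc3)cc(C(F)(F)F)c12` differs from compound 3 in one place: a group of 9 heavy atoms (7 carbon, 1 nitrogen, 1 sulfur; one five-membered aromatic ring with 1 hetero atom, one six-membered non-aromatic ring with 1 hetero atom) in place of one oxygen atom, on a carbonyl carbon. Among the measured compounds shown here, no two measured compounds differ in only one place, so no measured step shows what such a change does here. With all three values at the limit, the expected step is none beyond the usual scatter. Compound 4 is expected at 22000 nM, within 7000 nM to 60000 nM. The expected step is a step that the limit leaves unreadable from compound 3 to compound 4.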

Compound 4, half-maximal cytotoxic concentration: > 20000 nM
Compound 4 gave a limit, no number; the forecaster's own chance of this, stated with the estimate: 60%; the middle value lies beyond the limit too.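

Among the compounds shown here, compound 3 and compound 4 each give a limit rather than a number in this assay, so no step between them can be read. The compounds shown leave open at what concentration any of them would become toxic to these cells: the limit of > 20000 nM in this assay, at which 4 of the 4 values shown sit.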